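From methyl to 4-methylphenyl on a sulfonyl sulfur

The source may hold more compounds than are shown below. What is called first, only, known or untested is meant among the compounds shown, and "the series" means these compounds.

Three compounds have been measured so far in a functional assay on MCF7 cells (Homo sapiens) for antiproliferative activity, read by sulforhodamine B assay, with a stated time of 72 h (a higher number here means a weaker inhibitor, a lower number a stronger inhibitor), and give these values:

compound 1 `COc1cccc(/C=C2\CCC=CC2=O)c1` gives 2030 nM
compound 2 `COc1cc(OC)c(/C=C2\CCC=CC2=O)c(OC)c1` gives 9080 nM
compound 3 `COc1cc(/C=C2\CN(S(C)(=O)=O)C=CC2=O)cc(OC)c1OC` gives 17600 nM

Compound 3 at 17600 nM cannot be told apart from compound 2 at 9080 nM. The two lie within the usual scatter of repeated measurements. Compound 1 at 2030 nM has a number lower than compound 3 by more than that scatter, so compound 3 is the weaker inhibitor of that pair.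

For the measured compounds named here, no two measured compounds differ in only one place, so the data give no direct guide to a change on the sulfonyl group. Compound 4 `COc1cc(/C=C2\CN(S(=O)(=O)c3ccc(C)cc3)C=CC2=O)cc(OC)c1OC` keeps the core of compound 3 and carries one change: 4-methylphenyl in place of methyl on a sulfonyl sulfur, with 4-methylphenyl in place of methyl on a sulfonyl sulfur.

Without a guide, the expectation stays close to compound 3 at 17600 nM in this assay and foresees no shift beyond the scatter, with only a slight lean towards a lower number. The expected change is a 1.5-fold lower number from compound 3 to compound 4 (0.17 log units; within the scatter) and it remains an estimate. For compound 4 the estimated value is 12000 nM, with an expected range from 4000 nM to 35000 nM.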

Compound 4, half-maximal inhibitory concentration: 19200 nM
Beside the measured number, compound 4's estimate is 1.6-fold (0.20 log units) below it; measured number inside the range.
By their numbers in this assay, from the lowest: compound 1; then compounds 2, 3 and 4 (each within the scatter of the next, the first and the last beyond it).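

In this assay, for the compounds shown here, the change from methyl to 4-methylphenyl on a sulfonyl sulfur gives a 1.1-fold higher number from compound 3 to compound 4 (0.04 log units; within the scatter) and so offers the first direct comparison at this position, with only this one group different between the two compounds. A methyl group with no ring and a 4-methylphenyl group with one six-membered aromatic ring of carbon only therefore cannot be told apart in this read-out, so this particular swap on the sulfonyl sulfur leaves the antiproliferative number unchanged within the usual scatter. No measurement offered here accounts for that result, so the closeness of the two numbers remains an observation without an explanation.

Going by these compounds, this single pair says nothing about groups of other kinds on the sulfonyl sulfur, so it remains open whether a longer chain such as butyl, a phenyl ring carrying an amine or a carboxylic acid, or a ring containing nitrogen such as pyridine would behave in the same way. On these data alone, it is also open whether an acetyl group in place of the whole sulfonyl unit on the ring nitrogen would give a number that differs from those of this pair.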